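Replacing 2-Bromophenyl with 3-Fluorophenyl on the Ring Nitrogen

The compounds below may be only part of what the source reports. "The series", "measured", "known", "first", "only" and "open" are said of these compounds alone.

Compound 1, `CCCn1c(=O)[nH]c2nc(-c3ccc(S(=O)(=O)N4CCN(Cc5ccc(Br)cc5)CC4)cc3)[nH]c2c1=O`: 31%
Compound 2, `CCCn1c(=O)[nH]c2nc(-c3ccc(S(=O)(=O)N4CCN(c5ccccc5Br)CC4)cc3)[nH]c2c1=O`: 28%

In an assay on CHO cells for displacement of a labelled ligand from adenosine receptor A1 (Homo sapiens), read by scintillation counting, with a stated time of 90 min, tested at 1 uM, in the presence of a further agent that is not named here (a lower number here means less inhibition, a higher number more inhibition at the concentration tested (going by the name of the read-out)), compound 1 gives 31% and compound 2 gives 28%. Compound 2 holds the lower of the two numbers, but the step of a number 3 percentage points lower from compound 1 to compound 2 (within the scatter) lies within the scatter, so the two are not distinguishable. Compound 3, `CCCn1c(=O)[nH]c2nc(-c3ccc(S(=O)(=O)N4CCN(c5cccc(F)c5)CC4)cc3)[nH]c2c1=O`, differs from compound 2 by 3-fluorophenyl in place of 2-bromophenyl on an amine nitrogen in a ring. Going by the values given here, the only measured step also exchanged the group on this ring nitrogen and was small. A similarly small step a number 1 percentage points lower from compound 2 to compound 3 (within the scatter) is therefore expected. Compound 3 is estimated at 27%, between 12% and 42%.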

Compound 3, a percentage reported as inhibition, at one concentration (the size of the read-out at that concentration, not a potency): 34%
Compound 3: the middle estimate sits 7 percentage points below what was measured; measured number inside the range.
By their numbers in this assay, from the lowest: compounds 2, 1 and 3 (each within the scatter of the next).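

The step of a number 6 percentage points higher from compound 2 to compound 3 (within the scatter) and the step of a number 3 percentage points higher from compound 1 to compound 3 (within the scatter) in this assay show that 3-fluorophenyl on this ring nitrogen cannot be told apart from 2-bromophenyl or 4-bromobenzyl. Fluorine in place of bromine on the aromatic ring therefore gives no readable change here. No measured evidence bears on this result. Going by these compounds, whether a different kind of group on this nitrogen, such as a carboxylic acid or a longer alkyl chain, would give a step beyond the scatter remains open.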